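The source may report more compounds than this note shows. Statements on the series, on what has been measured and on what is new or still open speak of the compounds shown alone.

Measured in a functional assay on B16-F10 cells (Mus musculus) for antiproliferative activity, read by MTT assay, with a stated time of 48 h; on this read-out lower numbers stand for stronger inhibition and higher numbers for weaker inhibition:
- compound 1 `O=C(/C=C/c1ccc(O)c(O)c1)N1CCN(c2ccccc2F)CC1` gives 2.43 ug/mL
- compound 2 `O=C(/C=C/c1ccc(O)c(O)c1)N1CCN(c2ccc(F)cc2)CC1` gives 1.68 ug/mL
- compound 3 `O=C(/C=C/c1ccc(O)c(O)c1)N1CCN(c2cccc(Cl)c2)CC1` gives 1.71 ug/mL

Compound 3 at 1.71 ug/mL stands within the scatter of both other compounds, as shown by a 1.0-fold higher number from compound 2 to compound 3 (0.01 log units; within the scatter) and a 1.4-fold lower number from compound 1 to compound 3 (0.15 log units; within the scatter). Compound 4 `COc1ccccc1N1CCN(C(=O)/C=C/c2ccc(O)c(O)c2)CC1` carries 2-methoxyphenyl in place of 3-chlorophenyl on an amine nitrogen in a ring. For the measured compounds named here, the nearest evidence is a 1.4-fold lower number from compound 1 to compound 2 (0.16 log units; within the scatter), which like the other two steps changes only this aromatic group. Going by the values given here, no compound with a methoxy group has been measured. A step beyond the scatter is therefore not expected, and the estimate is a 1.2-fold higher number from compound 3 to compound 4 (0.09 log units; within the scatter). For compound 4 the expected value is 2.1 ug/mL, with an estimated range from 1.1 ug/mL to 4 ug/mL.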

Compound 4, half-maximal inhibitory concentration: 1.23 ug/mL
Estimate against measurement, compound 4: 1.7-fold (0.23 log units) above, within the range that was stated.
By their numbers in this assay, from the lowest: compounds 4, 2, 3 and 1 (each within the scatter of the next).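

In this assay, compound 4 is the only one shown whose aromatic group carries an oxygen and a hydrogen-bond acceptor, yet a 1.4-fold lower number from compound 3 to compound 4 (0.14 log units; within the scatter) and a 1.4-fold lower number from compound 2 to compound 4 (0.14 log units; within the scatter) leave it level with the halogen-bearing compounds. Methoxy in place of fluoro on an aromatic carbon gives a 2.0-fold lower number from compound 1 to compound 4 (0.30 log units; within the scatter) and is likewise printed as within the scatter, so no group on this amine nitrogen has yet given a step beyond it. No measurement available here explains these numbers.

On these data alone, whether an amine or a carboxylic acid on this aromatic ring would give a step beyond the scatter remains open. The same holds for a longer chain in place of methoxy.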